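Swapping the amide ring partner in a sulfonylpiperidine series

A few compounds are considered here, and "the series" means these few. Any claim that something is new, unique, unknown or untested is made for them only; others in the source may bear on it.

Measured compounds:
compound 1 `CCN(CC)S(=O)(=O)c1ccc(S(=O)(=O)N2CCC[C@@H](C(=O)N3CCC(F)(F)CC3)C2)cc1` — 16 nM
compound 2 `CCC(CC)S(=O)(=O)c1ccc(S(=O)(=O)N2CCC[C@@H](C(=O)N3CCC(F)(F)CC3)C2)cc1` — 13 nM
compound 3 `CCN(CC)C(=O)c1ccc(S(=O)(=O)N2CCC[C@@H](C(=O)N3CCC(F)(F)CC3)C2)cc1` — 70 nM

In a functional assay on MIA PaCa-2 cells (Homo sapiens) for inhibition, read by MTT assay, with a stated time of 7 days (a higher number here means a weaker inhibitor, a lower number a stronger inhibitor), compound 1 gives 16 nM, the second highest of the three numbers. Its nearest neighbour is compound 2, which gives 13 nM, and the step of a 1.2-fold lower number from compound 1 to compound 2 (0.09 log units; within the scatter) lies within the scatter. Its furthest neighbour is compound 3, which gives 70 nM; the step of a 4.4-fold higher number from compound 1 to compound 3 (0.64 log units; beyond the scatter) is beyond the scatter, as is a 5.4-fold higher number from compound 2 to compound 3 (0.73 log units; beyond the scatter).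

Compound 4 `CCN(CC)S(=O)(=O)c1ccc(S(=O)(=O)N2CCC[C@@H](C(=O)N3CC[C@H](OC)C3)C2)cc1` has not yet been measured. It differs from compound 1 in one place: 3-methoxypyrrolidin-1-yl in place of 4,4-difluoropiperidin-1-yl on a carbonyl carbon

Within the data shown here, none of the measured steps touches this part of the shared core. The steps from compound 1 to compound 2 and to compound 3 change a group on a sulfonyl sulfur or on an aromatic carbon, while the diethylsulfamoyl side of compound 4 is unchanged from compound 1. The effect of replacing the 4,4-difluoropiperidin-1-yl with a 3-methoxypyrrolidin-1-yl on the carbonyl carbon is therefore unknown from these data.

Among the measured compounds shown here, with no step bearing on the change, compound 4 is expected to stay near compound 1, the expected step being a 1.6-fold higher number from compound 1 to compound 4 (0.19 log units; within the scatter), with a wide range to reflect the uncertainty. Compound 4 is estimated at 25 nM, between 6 nM and 120 nM.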

Compound 4, half-maximal inhibitory concentration: 2460 nM
Compound 4: the middle estimate sits 98-fold (1.99 log units) below what was measured; the measured number lies above the stated range.
By their numbers in this assay, from the lowest: compounds 2 and 1 (each within the scatter of the next); then compound 3; then compound 4.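

In this assay, the amide ring partner on the carbonyl carbon turns out to matter a great deal: 3-methoxypyrrolidin-1-yl in place of 4,4-difluoropiperidin-1-yl gives a 150-fold higher number from compound 1 to compound 4 (2.19 log units; beyond the scatter), a large step. Among these compounds, that step far exceeds a 4.4-fold higher number from compound 1 to compound 3 (0.64 log units; beyond the scatter) and a 1.2-fold lower number from compound 1 to compound 2 (0.09 log units; within the scatter), the changes seen earlier on an aromatic carbon and on a sulfonyl sulfur, so this position is more sensitive to this change than the earlier compounds could show. Nothing in the data given accounts for the loss.

The change replaces a six-membered ring with a five-membered one, removes the fluorine atoms, and adds a methoxy group and a defined stereocentre all at once, and the compounds shown do not separate these differences; a 4-methoxypiperidin-1-yl, a 3,3-difluoropyrrolidin-1-yl or the opposite stereoisomer of the 3-methoxypyrrolidin-1-yl group would each isolate one of them. On these data alone, it also stays open whether the same ring swap would have a step of similar size with the (pentan-3-yl)sulfonyl group of compound 2 or the diethylcarbamoyl group of compound 3.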